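This account rests on a few compounds, and the source may have more. Where it says the series, first, only, none or still open, it means among the compounds named here.

Measured so far:
- compound 1 `CC(C)(C)c1nc(-c2ccc[nH]2)c2cc(C(N)=O)c(N)nc2n1`: 130000 nM
- compound 2 `N#Cc1c(N)nc2nc(Cc3ccccc3)ncc2c1N`: 13000 nM
- compound 3 `CC(C)(C)c1nc(CCCCCC#N)c2c(N)c(C#N)c(N)nc2n1`: 6000 nM

All three compounds were tested in a physicochemical assay for solubility, in phosphate buffer, with a stated time of 18 h; a lower number here means a less soluble compound, a higher number a more soluble compound. Compound 3 gives the lowest of the three numbers: compound 2 stands above it by a margin beyond the scatter, and compound 1 stands furthest above it.

The next compound, compound 4 `CC(C)(C)c1nc(-c2ncco2)c2c(N)c(C#N)c(N)nc2n1`, has not yet been measured. It differs from compound 3 in one place (1,3-oxazol-2-yl in place of 5-cyanopentyl on an aromatic carbon). A chain ending in a nitrile leaves, and a small five-membered aromatic ring enters instead. For the measured compounds named here, no measured pair shows this exact change, so the size of the step cannot be read from the data. Going by the values given here, since compound 1 gives 130000 nM and is the only other compound whose structure holds a five-membered aromatic ring, a modest step upward is expected for compound 4, estimated at a 1.5-fold higher number from compound 3 to compound 4 (0.18 log units; within the scatter). Compound 4 is therefore estimated to reach 9000 nM in this assay, within a range from 2500 nM to 35000 nM.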

Compound 4, solubility: 50000 nM
Compound 4: the middle estimate sits 5.6-fold (0.74 log units) below what was measured; measured number outside the range, above it.
By their numbers in this assay, from the lowest: compound 3; then compound 2; then compound 4; then compound 1.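

In this assay the exchange of 5-cyanopentyl for 1,3-oxazol-2-yl on this aromatic carbon gives an 8.3-fold higher number from compound 3 to compound 4 (0.92 log units; beyond the scatter) in a single change. For the compounds shown here, compound 3 and compound 4 form the first pair that differs in one place, so this is the first direct sign that the group at this position can shift the solubility reading beyond the scatter while the rest of the structure stays the same. The data shown hold no measurement that explains this step.

The change swaps an open chain ending in a nitrile for a five-membered aromatic ring, so the pair cannot separate the loss of the chain or its nitrile from the arrival of the ring. From the compounds shown here alone, a plain pentyl chain, a phenyl ring or an amine at this position would each help to separate those parts, and where any of them would fall remains open.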